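The source may hold more compounds than are shown below. What is called first, only, known or untested is meant among the compounds shown, and "the series" means these compounds.

Measured so far:
Compound 1 `Nc1nc(Cl)c(-c2cc3ccccc3s2)c(N[C@@H]2C[C@H](CO)[C@@H](O)[C@H]2O)n1` gives > 25000 nM in an ADME assay on cells (Homo sapiens) for cytotoxicity, read by polymerase chain reaction, with a stated time of 3 days (on this read-out lower numbers stand for higher toxicity in this test and higher numbers for lower toxicity in this test), which is a limit of the assay and not a number.
Compound 2 `Nc1ncc(-c2nc3ccccc3s2)c(N[C@@H]2C[C@H](CO)[C@@H](O)[C@H]2O)n1` gives > 25000 nM in this assay, again a limit rather than a number.
Compound 3 `Cc1nc(NCCOC(C)C)nc(N[C@@H]2C[C@H](CO)[C@@H](O)[C@H]2O)c1-c1nc2ccccc2s1` gives 8000 nM in this assay.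

Compound 3 therefore stands alone in showing an actual number: the other two results are the limit of > 25000 nM in this assay, at which 2 of the 3 values shown sit, so no ordering among the three compounds can be read off beyond the fact that compound 3 reached a measurable half-maximal cytotoxic concentration while compounds 1 and 2 did not within the tested range. For the measured compounds named here, no step between two measured compounds that differ in a single place is available here, so there is no direct guide to how a single change shifts the read-out.

Compound 4 `Cc1nc(NCc2ccccn2)nc(N[C@@H]2C[C@H](CO)[C@@H](O)[C@H]2O)c1-c1nc2ccccc2s1` is not yet measured. It differs from compound 3 in one place: pyridin-2-yl in place of isopropoxymethyl on a saturated chain carbon bound to a nitrogen on an aromatic ring. The change swaps one chain end for another of similar size, each carrying one hydrogen-bond acceptor and no charge. Going by the values given here, with no measured step to lean on, the expectation is a step from compound 3 to compound 4 of a 1.3-fold higher number from compound 3 to compound 4 (0.10 log units; within the scatter), that is, no change beyond the usual scatter. Compound 4 is accordingly estimated at 10000 nM, within 3000 nM to 25000 nM.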

Compound 4, half-maximal cytotoxic concentration: 13000 nM
For compound 4 the middle estimate is 1.3-fold (0.11 log units) below the measured one; low and high end bracket the measured number.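

For the compounds shown here, this is the first step between two compounds that differ in one place, and in this assay putting pyridin-2-yl in place of isopropoxymethyl on a saturated chain carbon bound to a nitrogen on an aromatic ring gives a 1.6-fold higher number from compound 3 to compound 4 (0.21 log units; within the scatter). At this place, then, an open chain end and a six-membered aromatic ring with one hetero atom give values that cannot be told apart, and both compounds still give a measurable number rather than a limit. Going by these compounds alone, compound 1 and compound 2 differ from these two in more than one place, and each gives only a limit of the assay, so they add no further step here: the limit of > 25000 nM in this assay, at which 2 of the 4 values shown sit.

One exchange at one place says nothing yet about chain ends of a different kind, such as a primary amine, a carboxylic acid or a longer alkyl chain, any of which might move the read-out beyond the usual scatter. Going by these compounds, it also remains open whether pyridin-3-yl or a plain phenyl at the same place would give a similar value, and whether this exchange would give the same step on a different core.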